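Adding a Fluorine on the Alkene Linker

The source may hold more compounds than are shown below. What is called first, only, known or untested is meant among the compounds shown, and "the series" means these compounds.

Compound 1 `COc1cc2nc(N3CCN(C(=O)/C=C/c4ccccc4)CC3)nc(N)c2cc1OC` gives 0.692 nM in an assay on cell membranes for displacement of a labelled ligand from Adrenergic receptor alpha-1 (Rattus norvegicus), tested at 100 nM (a higher number here means a weaker inhibitor, a lower number a stronger inhibitor), the lowest number among the three measured compounds. Compound 2 `COc1cc2nc(N3CCN(C(=O)/C=C/c4ccc(F)cc4)CC3)nc(N)c2cc1OC` gives 22.9 nM in this assay, and compound 3 `COc1cc2nc(N3CCN(C(=O)/C=C/c4ccc(NC(=O)CBr)cc4)CC3)nc(N)c2cc1OC` gives 67.6 nM. Compound 4 `COc1cc2nc(N3CCN(C(=O)/C(F)=C/c4ccccc4)CC3)nc(N)c2cc1OC` differs from compound 1 by 1-fluoro-2-phenylethenyl in place of 2-phenylethenyl on a carbonyl carbon. Among the measured compounds shown here, no measured step touches this position; the nearest comparisons alter the aromatic ring instead, where a 33-fold higher number from compound 1 to compound 2 (1.52 log units; beyond the scatter) and a 98-fold higher number from compound 1 to compound 3 (1.99 log units; beyond the scatter) show that compound 1 loses a great deal on even a small addition. The change on the double bond is expected to weaken binding too, though by less than those ring changes. The step for compound 4 is expected to be a 7.2-fold higher number from compound 1 to compound 4 (0.86 log units; beyond the scatter). Compound 4 is therefore estimated at 5 nM, with a range from 1 nM to 40 nM.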

Compound 4, half-maximal inhibitory concentration: 39.8 nM
Compound 4: middle estimate off by 8.0-fold (0.90 log units), on the low side; the measured number falls inside the stated range.
By their numbers in this assay, from the lowest: compound 1; then compounds 2, 4 and 3 (each within the scatter of the next, the first and the last beyond it).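

In this assay, the double bond proves as sensitive as the aromatic ring: fluorine on this linker alone gives a 58-fold higher number from compound 1 to compound 4 (1.76 log units; beyond the scatter), a large loss like those seen on the ring. Where the single fluorine sits, on the linker or on the ring, makes no clear difference here, with a 1.7-fold higher number from compound 2 to compound 4 (0.24 log units; within the scatter). No available evidence explains why this small addition costs so much.

From the compounds shown here alone, whether the loss is specific to fluorine remains open, since a chlorine or a methyl group in the same place could give a different number.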